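A few compounds are considered here, and "the series" means these few. Any claim that something is new, unique, unknown or untested is made for them only; others in the source may bear on it.

Measured in a functional assay on cells (Neutrophil, Homo sapiens) for inhibition, with a stated time of 10 min; a higher number here means a weaker inhibitor, a lower number a stronger inhibitor:
Compound 1 `O=C(Nc1cccc2ccccc12)N1c2ccnn2CC1c1ccccc1`: > 1000 nM (a limit of the assay)
Compound 2 `NC(=O)c1cnn2c1N(C(=O)Nc1cccc(F)c1)C(c1ccccc1)C2`: 1.2 nM
Compound 3 `NC(=O)c1cnn2c1N(C(=O)Nc1ccc(F)cc1)C(c1ccccc1)C2`: 484 nM

Of the two exact numbers in this assay, compound 3 holds the higher, 484 nM. Compound 4 `NC(=O)c1cnn2c1N(C(=O)Nc1cccc3ccccc13)C(c1ccccc1)C2` keeps the core of compound 3 and changes one group: naphthalen-1-yl in place of 4-fluorophenyl on an amide-type nitrogen. Among the compounds with values here, the only measured step at this place is large: a 400-fold higher number from compound 2 to compound 3 (2.61 log units; beyond the scatter). A sizeable move in either direction is therefore possible in this assay, although no direction is firmly favoured. Compound 1 carries naphthalen-1-yl on a core that differs, and its value is a limit, > 1000 nM. The expected change is small as a central guess: a 1.2-fold lower number from compound 3 to compound 4 (0.08 log units; within the scatter). For compound 4 the estimate is 400 nM, with an expected range from 30 nM to 3000 nM.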

Compound 4, half-maximal inhibitory concentration: > 1000 nM
Compound 4: no number, only a limit; the forecaster's own chance of this, stated with the estimate: 25%; middle value at least 2.5-fold (0.39 log units) from the limit.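

In this assay compound 4 gives only a limit of the assay, > 1000 nM. On the shared core, naphthalen-1-yl on this amide-type nitrogen gives weaker inhibition than either fluorinated phenyl group, with an at least 2.0-fold higher number from compound 3 to compound 4 (0.31 log units; beyond the scatter) and an at least 830-fold higher number from compound 2 to compound 4 (2.92 log units; beyond the scatter). Compound 1 and compound 4 both give limits, so the step between them, carbamoyl in place of hydrogen, cannot be read: the limit of > 1000 nM in this assay, at which 2 of the 4 values shown sit.

Going by these compounds, the true size of the loss with naphthalen-1-yl remains open. So does the outcome with a cyclohexyl or benzyl group on this nitrogen.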